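Methoxycarbonyl Added to a Second Core: Expected Lipophilicity

This account rests on a few compounds, and the source may have more. Where it says the series, first, only, none or still open, it means among the compounds named here.

Compound 1 `COC(=O)c1ccc2ccc(C(=O)N(C)C)c-2cc1`: 2.3
Compound 2 `CN(C)C(=O)c1ccc2cccccc1-2`: 2.1
Compound 3 `CN(C)C(=O)c1cn(C)c2ccccc12`: 1.8

Three compounds were measured in a physicochemical assay for lipophilicity, read by HPLC, measured as octanol-water partition, at pH 2; on this read-out lower numbers stand for lower lipophilicity and higher numbers for higher lipophilicity. Compound 1 differs from compound 2 by methoxycarbonyl in place of hydrogen on an aromatic carbon, and this assay gave a number 0.20 log units higher from compound 2 to compound 1 (within the scatter). Compound 3 rests on a different core; the difference between the two cores is not broken down here. Its value sits within the scatter of compound 2, while compound 1 stands beyond the scatter above it.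

Compound 4 `COC(=O)c1ccc2c(C(=O)N(C)C)cn(C)c2c1` is not yet measured. It differs from compound 3 by methoxycarbonyl in place of hydrogen on an aromatic carbon. This is the same kind of change as from compound 2 to compound 1, though the place differs: there the group sat on a seven-membered aromatic ring of carbon only, here on a six-membered aromatic ring of carbon only, meta to a fused ring and para to a fused ring. Because the earlier change gave a number 0.20 log units higher from compound 2 to compound 1 (within the scatter), a step of about a number 0.20 log units higher from compound 3 to compound 4 (within the scatter) is expected here. Compound 4 is therefore estimated at 2, between 1.6 and 2.5.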

Compound 4, distribution coefficient: 1.9
Compound 4: the middle estimate sits 0.10 log units above what was measured; measured number inside the range.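

In this assay, methoxycarbonyl in place of hydrogen on an aromatic carbon gave a number 0.10 log units higher from compound 3 to compound 4 (within the scatter), and on the other core it gave a number 0.20 log units higher from compound 2 to compound 1 (within the scatter), so in these two pairs the step stays within the scatter on both cores. Two pairs cannot show that the group has no effect on this read-out, nor that the step would stay this small on further cores, and the group sits in a different place on each core. Nothing measured here explains the result.

The compounds shown leave open whether an amine or a carboxylic acid in place of that hydrogen would give a similar step. They also leave open what methoxycarbonyl would do on another carbon of the same ring.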